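Swapping benzyl for 4-chlorophenyl on a urea nitrogen

The compounds below may be only part of what the source reports. "The series", "measured", "known", "first", "only" and "open" are said of these compounds alone.

Three members of this series have been measured in a functional assay on T98G cells (Homo sapiens) for inhibition, read by MTT assay, with a stated time of 72 h; on this read-out higher numbers stand for weaker inhibition and lower numbers for stronger inhibition. Compound 1 `COc1cccc(NC(=S)NC2CC(C)(C)Oc3ccc(Br)cc32)c1` gives 87000 nM, compound 2 `CC1(C)CC(NC(=O)NCc2ccccc2)c2cc(Br)ccc2O1` gives 38000 nM, and compound 3 `CC1(C)CC(NC(=O)NCc2ccccc2)c2cc(Cl)ccc2O1` gives 15000 nM. Among the measured compounds shown here, compound 2 thus holds the second highest number of the three: compound 1 sits above it, while the single change from a 2.5-fold lower number from compound 2 to compound 3 (0.40 log units; beyond the scatter) describes the step down to compound 3. Compound 4 `CC1(C)CC(NC(=O)Nc2ccc(Cl)cc2)c2cc(Br)ccc2O1` differs from compound 2 by 4-chlorophenyl in place of benzyl on an amide-type nitrogen. For the measured compounds named here, no measured step alters this position, and compound 1, the only other compound carrying an aromatic ring directly on that nitrogen, differs in several places, so its higher value is only a weak hint. Compound 4 is therefore expected to show a 1.1-fold higher number from compound 2 to compound 4 (0.02 log units; within the scatter), with an estimated value of 40000 nM in a range from 15000 nM to 110000 nM.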

Compound 4, half-maximal inhibitory concentration: 27000 nM
The estimate for compound 4 lay 1.5-fold (0.17 log units) above the measured number; the measured number falls inside the stated range.
By their numbers in this assay, from the lowest: compounds 3, 4 and 2 (each within the scatter of the next, the first and the last beyond it); then compound 1.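

Swapping benzyl for 4-chlorophenyl on the urea nitrogen gives a 1.4-fold lower number from compound 2 to compound 4 (0.15 log units; within the scatter), so in this assay compound 2 and compound 4 cannot be told apart. This is the first single change shown at this nitrogen, and it indicates that an aromatic ring can sit directly on the nitrogen, without the carbon link of benzyl, and leave the number within the scatter. Nothing measured here bears on this result.

Still open, going by these compounds, is how a plain phenyl or a 4-methoxyphenyl on this nitrogen would compare. A longer chain, such as 2-phenylethyl, also remains untested among the compounds shown.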